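The source may report more compounds than this note shows. Statements on the series, on what has been measured and on what is new or still open speak of the compounds shown alone.

Compound 1 `COc1cc(/C=C/C(=O)C2=C(/C=C/c3ccc(O)c(OC)c3)NC(=O)NC2c2ccccc2O)ccc1O` and compound 3 `COc1cc(/C=C/C(=O)C2=C(/C=C/c3ccc(O)c(OC)c3)NC(=S)NC2c2ccccc2O)ccc1O` share much of their frame, but the difference between their two cores is not broken down here. In a functional assay on QG-56 cells (Homo sapiens) for cytotoxicity, read by MTT assay, with a stated time of 48 h (on this read-out higher numbers stand for weaker inhibition and lower numbers for stronger inhibition), compound 1 gives 100000 nM. In this assay compound 3 gives 50000 nM, and its gap to compound 1 lies within the usual scatter of such measurements. Compound 2 `COc1cc(/C=C/C(=O)C2=C(/C=C/c3ccc(O)c(OC)c3)NC(=O)NC2c2ccc(N(C)C)cc2)ccc1O` arises from compound 1 by a single change, (4-(dimethylamino)phenyl in place of 2-hydroxyphenyl on a saturated ring carbon), and in this assay compound 2 gives 12500 nM. That change brought an 8.0-fold lower number from compound 1 to compound 2 (0.90 log units; beyond the scatter). Compound 4 `COc1cc(/C=C/C(=O)C2=C(/C=C/c3ccc(O)c(OC)c3)NC(=S)NC2c2ccc(N(C)C)cc2)ccc1O` is related to compound 3 by the same change, (4-(dimethylamino)phenyl in place of 2-hydroxyphenyl on a saturated ring carbon), made on the core of compound 3 instead. Going by the values given here, only one earlier example of this change has been measured, so any expectation carries real uncertainty. Because that single earlier example gave an 8.0-fold lower number from compound 1 to compound 2 (0.90 log units; beyond the scatter), the step from compound 3 to compound 4 in this assay is expected to be a 7.9-fold lower number from compound 3 to compound 4 (0.90 log units; beyond the scatter). Compound 4 is therefore estimated at 6300 nM in this assay, with a likely range from 2000 nM to 25000 nM.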

Compound 4, half-maximal inhibitory concentration: 25000 nM
For compound 4 the middle estimate is 4.0-fold (0.60 log units) below the measured one; the range from low to high includes it.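

In this assay, putting 4-(dimethylamino)phenyl in place of 2-hydroxyphenyl on the core of compound 3 gave a 2.0-fold lower number from compound 3 to compound 4 (0.30 log units; within the scatter), a step too small to separate from the ordinary variation between repeated measurements. The same change therefore did not carry over at its earlier size, and the difference between its effects on the two cores is larger than such variation would explain: the same change on two cores in this assay, an 8.0-fold lower number (0.90 log units; beyond the scatter) from compound 1 to compound 2 and a 2.0-fold lower number (0.30 log units; within the scatter) from compound 3 to compound 4, 4.0-fold (0.60 log units) apart, beyond the scatter of two such steps This shows that, for these two pairs of compounds, the size of the step depends on the core it is made on, but it does not show which feature of the cores is responsible or how the change would behave on any further core.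

The compounds shown leave open whether this dependence on the core is specific to these two groups, or would also appear with a plain phenyl or a 4-methoxyphenyl on the same ring carbon of both cores. They also leave open whether the same difference would appear in another cell line.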